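The compounds below may be only part of what the source reports. "The series", "measured", "known", "first", "only" and "open" are said of these compounds alone.

Measured so far:
compound 1 `C/C=C/C=C/C(=O)N(Cc1ccc(OC)c(O)c1)c1cc(OC)c(OC)c(OC)c1` — 180 nM
compound 2 `COc1ccc(CNc2cc(OC)c(OC)c(OC)c2)cc1Br` — 39800 nM
compound 3 `C/C=C/C(=O)N(Cc1ccc(OC)c(Br)c1)c1cc(OC)c(OC)c(OC)c1` — 10500 nM

In a functional assay on KYSE-450 cells (Homo sapiens) for inhibition, read by MTT assay, with a stated time of 48 h (on this read-out lower numbers stand for stronger inhibition and higher numbers for weaker inhibition), compound 1 gives 180 nM, compound 2 gives 39800 nM and compound 3 gives 10500 nM. Compound 2 holds the highest number of the three. Among the compounds with values here, its nearest neighbour is compound 3, and the only single-point step recorded is a 3.8-fold lower number from compound 2 to compound 3 (0.58 log units; beyond the scatter), from (prop-1-en-1-yl)carbonyl in place of hydrogen on a nitrogen on an aromatic ring. Compound 1 sits far lower, but it differs from compound 2 in more than one place, so no single step can be read off that pair.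

Compound 4 `COc1ccc(CNc2cc(OC)c(OC)c(OC)c2)cc1F` is not yet measured. Against compound 2 the change is fluoro in place of bromo on an aromatic carbon; the new group sits ortho to a methoxy group and meta to a large group, and the nitrogen on the aromatic ring keeps its hydrogen. Within the data shown here, no measured step bears on this change: the recorded step a 3.8-fold lower number from compound 2 to compound 3 (0.58 log units; beyond the scatter) concerns the nitrogen, not the halogen, and no other halogen swap has been measured. With nothing in the data pointing either way, the expectation for compound 4 in this assay is a number close to that of compound 2, a step of a 1.0-fold higher number from compound 2 to compound 4 (0.00 log units; within the scatter) that is not expected to reach beyond the scatter. Compound 4 is therefore estimated at 40000 nM, with a range from 15000 nM to 100000 nM.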

Compound 4, half-maximal inhibitory concentration: 46200 nM
The estimate for compound 4 lay 1.2-fold (0.06 log units) below the measured number, within the range that was stated.
By their numbers in this assay, from the lowest: compound 1; then compound 3; then compounds 2 and 4 (each within the scatter of the next).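

In this assay, the swap of bromo for fluoro on the aromatic carbon ortho to a methoxy group gives a 1.2-fold higher number from compound 2 to compound 4 (0.06 log units; within the scatter), so the two compounds cannot be told apart on this read-out. Within the data shown here, this is the first halogen swap: the earlier step concerned only the nitrogen, whereas this one shows that, with the hydrogen kept on that nitrogen, bromo and fluoro read alike at this position. No measurement at hand bears on why the two halogens read alike.

Whether this holds once the nitrogen carries the (prop-1-en-1-yl)carbonyl group of compound 3 remains open, since a fluoro counterpart of compound 3 is not among the compounds shown. Also open, on these data alone, is whether a group of another kind on this aromatic carbon, such as an amine or a nitrile, would shift the number beyond the scatter, or whether this position tolerates such changes as it does the exchange of one halogen for another.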